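Methylcarbamoyl in place of carboxy: half-life outlook

This account rests on a few compounds, and the source may have more. Where it says the series, first, only, none or still open, it means among the compounds named here.

Among the measured compounds shown here, compound 2 `O=C(O)c1ccc(C(=O)C2=C(O)C(=O)N(c3ccc(-c4ccon4)cc3)C2C2CCCCC2)cc1` gives 1.9 h in an ADME assay on the whole organism (Rattus norvegicus) for metabolic stability (a lower number here means that the compound disappears faster, a higher number that the compound lasts longer), the highest of the two numbers so far, though its nearest neighbour sits within the scatter. Compound 1 `O=C(C1=C(O)C(=O)N(c2ccc(-c3ccon3)cc2)C1C1CCCCC1)c1ccc(CO)cc1` gives 1.4 h in this assay, and the step of a 1.4-fold higher number from compound 1 to compound 2 (0.13 log units; within the scatter) is within the scatter. Compound 3 `CNC(=O)c1ccc(C(=O)C2=C(O)C(=O)N(c3ccc(-c4ccon4)cc3)C2C2CCCCC2)cc1` differs from compound 2 by methylamino in place of hydroxy on a carbonyl carbon, that is methylcarbamoyl in place of carboxy. For the measured compounds named here, the only measured step, a 1.4-fold higher number from compound 1 to compound 2 (0.13 log units; within the scatter), concerns a different exchange, carboxy in place of hydroxymethyl on an aromatic carbon, and stayed within the scatter; no measured step exchanges a carboxy for a methylcarbamoyl. Going by the values given here, with one small step as the sole guide, no change beyond the scatter is expected in this assay in either direction. For compound 3 the expected value is 1.8 h, with a range from 0.8 h to 4 h, meaning an expected step of a 1.1-fold lower number from compound 2 to compound 3 (0.02 log units; within the scatter) that should remain within the scatter.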

Compound 3, half-life: 0.7 h
The estimate for compound 3 lay 2.6-fold (0.41 log units) above the measured number; the whole stated range lies above it.
By their numbers in this assay, from the lowest: compounds 3, 1 and 2 (each within the scatter of the next, the first and the last beyond it).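

In this assay, among the compounds shown here, this carbonyl carbon gives the first step beyond the scatter: methylamino in place of hydroxy yields a 2.7-fold lower number from compound 2 to compound 3 (0.43 log units; beyond the scatter). Methylcarbamoyl in place of hydroxymethyl gives a 2.0-fold lower number from compound 1 to compound 3 (0.30 log units; within the scatter), so the carboxy and methylcarbamoyl groups are separated by the half-life, while the hydroxymethyl group is not clearly separated from either. Nothing available explains the step between the carboxy and methylcarbamoyl groups.

Open, going by these compounds, is how an unsubstituted carboxamide or a longer chain such as ethylamino on the same carbonyl carbon would compare with compound 2 and compound 3 in this assay. On these data alone, a dimethylamino group at this place is equally open, so the series does not yet show whether the lower number is tied to methylamino alone or extends to other amides.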